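This account rests on a few compounds, and the source may have more. Where it says the series, first, only, none or still open, it means among the compounds named here.

The series shares one core, with a urea on one end and a nicotinamide-bearing ring on the other. Among the measured compounds shown here, compound 1 `O=C(Nc1ccc(Cl)cc1)Nc1cccc(-c2nc(-c3ccc(NC(=O)c4cccnc4)cc3Cl)no2)c1` is the first member. In a functional assay on MDA-MB-231 cells (Homo sapiens) for antiproliferative activity, read by MTT assay, with a stated time of 72 h (on this read-out lower numbers stand for stronger inhibition and higher numbers for weaker inhibition), compound 1 gives only a limit of the assay, > 10000 nM. Compound 2 `CS(=O)(=O)Nc1cccc(NC(=O)Nc2cccc(-c3nc(-c4ccc(NC(=O)c5cccnc5)cc4Cl)no3)c2)c1` carries a 3-(methanesulfonamido)phenyl in place of the 4-chlorophenyl on an amide-type nitrogen. In this assay compound 2 likewise gives only a limit, > 10000 nM. The step that the two limits leave unreadable from compound 1 to compound 2 therefore cannot be read, and compound 2 stands at the limit, where the other value also sits (the limit of > 10000 nM in this assay, at which 2 of the 2 values shown sit). Compound 3 `CS(=O)(=O)Nc1ccc(NC(=O)Nc2cccc(-c3nc(-c4ccc(NC(=O)c5cccnc5)cc4Cl)no3)c2)cc1Br` differs from compound 2 by 3-bromo-4-(methanesulfonamido)phenyl in place of 3-(methanesulfonamido)phenyl on an amide-type nitrogen. For the measured compounds named here, no measured step bears on this change with a readable size; the only step known is unreadable. With both known values at the limit, compound 3 is expected to stay near it, an expected step that the limit leaves unreadable from compound 2 to compound 3, and its estimated value in this assay is 15000 nM, in a range from 3000 nM to 60000 nM.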

Compound 3, half-maximal inhibitory concentration: 700 nM
Compound 3: middle estimate off by 21-fold (1.33 log units), on the high side; measured number outside the range, below it.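

In this assay, among the compounds shown here, the 3-bromo-4-(methanesulfonamido)phenyl on the amide-type nitrogen gives an at least 14-fold lower number from compound 2 to compound 3 (1.15 log units; beyond the scatter), the first readable change at this position, and it shows that the group on this nitrogen can decide whether the series registers any activity at all. Set against the 4-chlorophenyl, the same group gives an at least 14-fold lower number from compound 1 to compound 3 (1.15 log units; beyond the scatter), so this result does not depend on a single reference group. For the compounds shown here, compound 3 is the only one of the three compounds to come off the limit: the limit of > 10000 nM in this assay, at which 2 of the 3 values shown sit.

The change from compound 2 to compound 3 both adds a bromine and alters where the methanesulfonamido group stands, and the compounds shown do not separate these two parts. A plain 4-(methanesulfonamido)phenyl, or a 3-chloro-4-(methanesulfonamido)phenyl, would show how much depends on the bromine itself.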